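The compounds below may be only part of what the source reports. "The series", "measured", "known", "first", "only" and "open" are said of these compounds alone.

Two compounds of the series have a number in a physicochemical assay for solubility, in phosphate buffer, with a stated time of 18 h, at pH 7.4; on this read-out lower numbers stand for lower solubility and higher numbers for higher solubility. Compound 1 `CCOC(=O)CNc1nc(-n2nc(-c3ccccn3)nc2N)c2cc(OC)c(OC)cc2n1` gives 48000 nM in this assay. Compound 2 `COc1cc2ncnc(-n3nc(-c4ccccn4)nc3N)c2cc1OCc1ccccc1` gives 58000 nM in this assay; its number and that of compound 1 lie within the usual scatter of each other, so the two stand together and neither can be called the more soluble.

Compound 3 `CCOC(=O)NCCCOc1cc2c(-n3nc(-c4ccccn4)nc3N)ncnc2cc1OC` carries the change (2-((ethoxycarbonyl)amino)ethyl in place of phenyl on a saturated chain carbon bound to an oxygen on an aromatic ring). Among the measured compounds shown here, no measured pair shows this change, so nothing in the data fixes its size. The expectation for compound 3 is a step upward in this assay of modest size, at the edge of the scatter, estimated as a 1.6-fold higher number from compound 2 to compound 3 (0.19 log units; within the scatter). Compound 3 is therefore expected to come out at about 90000 nM in this assay, with a range from 35000 nM to 250000 nM.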

Compound 3, solubility: 16000 nM
Compound 3: the middle estimate sits 5.6-fold (0.75 log units) above what was measured; measured number outside the range, below it.
By their numbers in this assay, from the lowest: compound 3; then compounds 1 and 2 (each within the scatter of the next).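

In this assay, the place on a saturated chain carbon bound to an oxygen on an aromatic ring now has its first measured step: 2-((ethoxycarbonyl)amino)ethyl in place of phenyl gives a 3.6-fold lower number from compound 2 to compound 3 (0.56 log units; beyond the scatter). The number therefore moves beyond the scatter with the group carried at this place, which compounds 1 and 2 alone could not show, and replacing the aromatic ring with this open chain does not raise it. No measurement at hand accounts for the direction of this step.

The compounds shown leave open whether the lower number goes with the loss of the phenyl ring or with the ethoxycarbonyl end of the chain. A propoxy chain ending in an amine or a carboxylic acid, or a plain alkyl chain, at the same place would separate the two.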